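Amino for hydroxy on the cinnamide aryl ring

The source may report more compounds than this note shows. Statements on the series, on what has been measured and on what is new or still open speak of the compounds shown alone.

Three compounds of the series carry a number in an assay on isolated protein for displacement of a labelled ligand from melanin-concentrating hormone receptor 1 (Homo sapiens); on this read-out higher numbers stand for weaker inhibition and lower numbers for stronger inhibition. Compound 1 `CCCc1cc(OC)c2cc(NC(=O)/C=C/c3ccc(C(F)(F)F)cc3)ccc2n1` gives 26 nM in this assay, and compound 3 `Nc1cc(-c2ccccc2)nc2ccc(NC(=O)/C=C/c3ccc(C(F)(F)F)cc3)cc12` gives 18.5 nM in this assay. Compound 2 `CCCc1cc(N)c2cc(NC(=O)/C=C/c3ccc(O)cc3)ccc2n1` gives 1100 nM in this assay, the highest of the three numbers; its gaps to compound 1 and to compound 3 are both beyond the scatter, so compound 2 is the weakest of the measured set. Compound 2 differs from compound 1 at more than one place, so no single change accounts for the gap between them.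

Compound 4 `CCCc1cc(N)c2cc(NC(=O)/C=C/c3ccc(N)cc3)ccc2n1` has not yet been measured. It is made from compound 2 by amino in place of hydroxy on an aromatic carbon, at the position para to a large group on the six-membered aromatic ring of carbon only. The counted difference keeps the numbers of hydrogen-bond donors and acceptors unchanged and adds no ring and no charge. For the measured compounds named here, no measured pair isolates this change, so the expectation rests on compound 2 alone. The step from compound 2 to compound 4 is expected to be a 1.2-fold lower number from compound 2 to compound 4 (0.09 log units; within the scatter), which lies within the scatter. Compound 4 is accordingly estimated at 900 nM in this assay, with a range from 300 nM to 3000 nM.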

Compound 4, half-maximal inhibitory concentration: 190 nM
Beside the measured number, compound 4's estimate is 4.7-fold (0.68 log units) above it, outside the stated range (below it).
By their numbers in this assay, from the lowest: compounds 3 and 1 (each within the scatter of the next); then compound 4; then compound 2.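

For the compounds shown here, the step, a 5.8-fold lower number from compound 2 to compound 4 (0.76 log units; beyond the scatter), in this assay is the first that isolates one place, and it shows that the position para to a large group on the six-membered aromatic ring of carbon only responds to the exchange of hydroxy for amino. The exchange of one heavy atom, with the same counts of hydrogen-bond donors and acceptors and no net charge on either group, is enough to carry the number beyond the scatter, so those counts alone do not predict the outcome at this position. No measurement bears on why the 4-aminophenyl compound gives the lower number, and the step remains an observation without an explanation.

Going by these compounds alone, still open is whether the same exchange gives a step of similar size on a core other than the one shared by compound 2 and compound 4. Also open, as far as these compounds go, is how this position responds to other groups, such as a dimethylamino group, an acetamide or a carboxylic acid, since a single pair cannot show a trend across substituents.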